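Bromo for chloro on the shared core, one halogen swap

The source may report more compounds than this note shows. Statements on the series, on what has been measured and on what is new or still open speak of the compounds shown alone.

Compound 1 `COc1cc(Cn2cc(COc3cccc(/C=C4\C(=O)Nc5ccccc54)c3)nn2)cc(OC)c1`: in a functional assay on BT-549 cells (Homo sapiens) for inhibition, read by MTT assay, with a stated time of 48 h (on this read-out higher numbers stand for weaker inhibition and lower numbers for stronger inhibition), compound 1 gives > 50000 nM, a limit of the assay.
Compound 2 `O=C1Nc2ccc(Cl)cc2/C1=C/c1cccc(OCc2cn(Cc3ccccc3)nn2)c1`: in this assay compound 2 gives "not determined" (no result reported).
Compound 3 `O=C1Nc2cc(Cl)ccc2/C1=C\c1cccc(OCc2cn(Cc3ccccc3)nn2)c1`: in this assay compound 3 gives > 50000 nM, again a limit of the assay.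

Compound 3 thus stands at the limit, and the numbers shown allow no ranking; the limit of > 50000 nM in this assay, at which 2 of the 3 values shown sit, marks where two of the three entries sit, the third having no number. Compound 4 `O=C1Nc2cc(Br)ccc2/C1=C\c1cccc(OCc2cn(Cc3ccccc3)nn2)c1` differs from compound 3 by bromo in place of chloro on an aromatic carbon. Going by the values given here, no step between measured compounds is known, and nothing in the values points in either direction. The step is expected to be a step that the limit leaves unreadable from compound 3 to compound 4, none beyond the scatter, with a limit again the most likely report. Compound 4 is estimated at 60000 nM in this assay, within 20000 nM to 200000 nM.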

Compound 4, half-maximal inhibitory concentration: > 50000 nM
Compound 4 gave a limit, no number; the forecaster's own chance of this, stated with the estimate: 75%; the middle value does not contradict the limit.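

Compound 3 and compound 4 both report only limits in this assay, so no step can be read for bromo in place of chloro on an aromatic carbon. The compounds shown leave open whether this swap changes inhibition at all, with readings stopping at one shared limit in this assay: the limit of > 50000 nM in this assay, at which 3 of the 4 values shown sit.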